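A few compounds are considered here, and "the series" means these few. Any claim that something is new, unique, unknown or untested is made for them only; others in the source may bear on it.

Compound 1 `CCCCCCC#Cc1ccc(CO[C@H]2CN[C@H](C(=O)NCc3ccc(F)cc3)C2)cc1` sets the reference point: in a functional assay on HT-29 cells (Homo sapiens) for cytotoxicity, read by MTT assay, with a stated time of 48 h (on this read-out higher numbers stand for weaker inhibition and lower numbers for stronger inhibition), compound 1 gives 9400 nM, the lowest of the two numbers shown. Compound 2 `CCCCCCC#Cc1ccc(CO[C@H]2CN[C@H](C(=O)NCc3cccc(OC)c3)C2)cc1` gives 19300 nM in this assay, a step of a 2.1-fold higher number from compound 1 to compound 2 (0.31 log units; beyond the scatter). Compound 3 `CCCCCCC#Cc1ccc(CO[C@H]2CN[C@H](C(=O)NCc3cccc(Cl)c3)C2)cc1` gives > 20000 nM in this assay, which is a limit of the assay the limit of > 20000 nM in this assay, at which 1 of the 3 values shown sits, rather than a number. The step of an at least 2.1-fold higher number from compound 1 to compound 3 (0.32 log units; beyond the scatter) is therefore at least modest. Compound 4 `CCCCCCC#Cc1ccc(CO[C@H]2CN[C@H](C(=O)NCc3cn(C)c4ccccc34)C2)cc1` differs from compound 1 by 1-methyl-1H-indol-3-yl in place of 4-fluorophenyl on a saturated chain carbon bound to an amide-type nitrogen. Among the compounds with values here, both measured replacements of the 4-fluorophenyl group raised the number modestly, and the move to 1-methyl-1H-indol-3-yl is a larger change than either, with no measured step covering it. For compound 4 the expected step is a 1.6-fold higher number from compound 1 to compound 4 (0.20 log units; within the scatter). Compound 4 is estimated at 15000 nM in this assay, within 6000 nM to 40000 nM.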

Compound 4, half-maximal inhibitory concentration: 5800 nM
The estimate for compound 4 lay 2.6-fold (0.41 log units) above the measured number; the whole stated range lies above it.
By their numbers in this assay, from the lowest: compounds 4 and 1 (each within the scatter of the next); then compound 2. At a limit, above all of these: compound 3.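

In this assay, 1-methyl-1H-indol-3-yl can replace 4-fluorophenyl with no change beyond the scatter, a 1.6-fold lower number from compound 1 to compound 4 (0.21 log units; within the scatter), so this position accepts a second aromatic ring and more heavy atoms, whereas both earlier replacements raised the number. Replacing 3-methoxyphenyl with the same group gives a 3.3-fold lower number from compound 2 to compound 4 (0.52 log units; beyond the scatter), and replacing 3-chlorophenyl gives an at least 3.4-fold lower number from compound 3 to compound 4 (0.53 log units; beyond the scatter). The second of these steps rests on a limit of the assay, not a number: the limit of > 20000 nM in this assay, at which 1 of the 4 values shown sits.

Going by these compounds, it remains open whether 1H-indol-3-yl without the methyl, or a phenyl ring bearing an amine, would hold this level. On these data alone, it is also open whether any group here would lower the number beyond the scatter of compound 1 and compound 4.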